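The source may report more compounds than this note shows. Statements on the series, on what has been measured and on what is new or still open speak of the compounds shown alone.

Compound 1, `CCOC(=O)c1ccc(NC(=O)N2CC2C#N)cc1`, gives 3300 nM in a functional assay on MCF7 cells (Homo sapiens) for inhibition; a lower number here means a stronger inhibitor, a higher number a weaker inhibitor.
Compound 2, `N#CC1CN1C(=O)NCc1ccccc1`, gives 3400 nM in this assay.
Compound 3, `CCCCNC(=O)N1CC1C#N`, gives only a limit in this assay.

Compound 1 and compound 2 lie within the usual scatter of each other in this assay, and both carry an aromatic group on the urea nitrogen. Going by the values given here, compound 3 is the one compound with a plain saturated chain there, and in this assay compound 3 is recorded only as a limit, > 12000 nM, not as a number. It stands at the limit of > 12000 nM in this assay, at which 1 of the 3 values shown sits, the weak end of what has been observed in this study.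

Compound 4, `CCNC(=O)N1CC1C#N`, keeps the shared core of compound 3 and differs from it in one place: hydrogen in place of ethyl on a saturated chain carbon, two bonds along the chain from an amide-type nitrogen. Among the compounds with values here, no pair of measured compounds differs by a change of this kind, so the size of this step cannot be read from the data. As far as these compounds go, compound 3 itself is only a limit, so the direction of any step from it is open. Compound 4 is expected to stay weak in this assay, with an estimated value of 15000 nM in the range 6000 nM to 40000 nM, and the step that the limit leaves unreadable from compound 3 to compound 4 is expected to be none beyond the scatter, most likely ending again in a limit rather than a number.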

Compound 4, half-maximal inhibitory concentration: 10000 nM
The estimate for compound 4 lay 1.5-fold (0.18 log units) above the measured number; the measured number falls inside the stated range.
By their numbers in this assay, from the lowest: compounds 1 and 2 (each within the scatter of the next); then compound 4. At a limit, above all of these: compound 3.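

With butyl shortened to ethyl, the chain position gives its first true number: in this assay, compound 4 gives 10000 nM. The change of ethyl to hydrogen on a saturated chain carbon, two bonds along the chain from an amide-type nitrogen, gives an at least 1.2-fold lower number from compound 3 to compound 4 (0.07 log units; that floor lies within the scatter), so the step has a floor but no measured size, and that floor does not show that shortening the chain changes the value beyond the scatter. Compound 3 remains a limit and not a number: the limit of > 12000 nM in this assay, at which 1 of the 4 values shown sits.

The compounds shown leave open how far compound 3 truly lies from compound 4, and so whether chain length matters here at all. They also leave open how a longer chain such as hexyl, or a chain ending in an amine or a carboxylic acid, would read in this assay.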